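The source may report more compounds than this note shows. Statements on the series, on what has been measured and on what is new or still open speak of the compounds shown alone.

Measured so far:
- compound 1, `COc1ccc(-c2cc(-c3cc(C(C)C)c(O)cc3C)[nH]c(=O)c2C#N)c(OC)c1`: 37.5%
- compound 2, `COc1cc(OC)c(-c2cc(-c3cc(C(C)C)c(O)cc3C)[nH]c(=O)c2C#N)c(OC)c1`: 52.6%

Both were tested in a functional assay for inhibition, tested at 40 ug/mL; on this read-out lower numbers stand for a weaker effect and higher numbers for a stronger effect at the one concentration tested. Within the data shown here, compound 1 stands at the lower of the two numbers, and the step of a number 15.1 percentage points higher from compound 1 to compound 2 (beyond the scatter) separates it from compound 2, the only other compound with a number. The new compound, compound 3 `Cc1cc(O)c(C(C)C)cc1-c1cc(-c2ccccc2Cl)c(C#N)c(=O)[nH]1`, has not been measured yet. It differs from compound 1 in one place: 2-chlorophenyl in place of 2,4-dimethoxyphenyl on an aromatic carbon. Among the measured compounds shown here, only one measured step exists, and it does not cover this change: it shows that placing a methoxy on an aromatic carbon raised inhibition by a modest amount, whereas here the 2,4-dimethoxyphenyl leaves altogether and a 2-chlorophenyl enters. For the measured compounds named here, that step gives a weak hint that the methoxy groups matter, so a modest loss from compound 1 to compound 3 seems somewhat more likely than a gain, but no measured compound carries a 2-chlorophenyl, which leaves the direction uncertain. The expected step is a number 7.5 percentage points lower from compound 1 to compound 3 (within the scatter). Compound 3 is estimated to give 30%, with a range from 10% to 50%.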

Compound 3, a percentage reported as inhibition, at one concentration (the size of the read-out at that concentration, not a potency): 20%
Compound 3: the middle estimate sits 10 percentage points above what was measured; the range from low to high includes it.
By their numbers in this assay, from the lowest: compound 3; then compound 1; then compound 2.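

In this assay, exchanging the 2,4-dimethoxyphenyl for 2-chlorophenyl gives a number 17.5 percentage points lower from compound 1 to compound 3 (beyond the scatter), so this position, opposite the ring nitrogen, responds to replacing the whole aromatic group and not only to adding a methoxy. The direction fits the earlier step, where adding a methoxy raised the number and this exchange, which removes both methoxy groups, lowered it; however, the same exchange also brings in a chlorine, so the drop cannot be assigned to the loss of the methoxy groups or the arrival of the chlorine alone. Nothing measured here explains why the number falls.

The compounds shown leave open how a plain phenyl, a 2-methoxyphenyl or a 4-methoxyphenyl would compare, and those groups could separate the contribution of each methoxy from that of the chlorine. They also leave open whether a ring bearing an amine or a carboxylic acid would be tolerated at this position, and how these differences at a single concentration would translate into potency.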